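Adding a Second Bromine to an Oxime Ether Series

The source may report more compounds than this note shows. Statements on the series, on what has been measured and on what is new or still open speak of the compounds shown alone.

Three compounds sharing one core have so far been measured in a functional assay on A549 cells (Homo sapiens) for antiproliferative activity, read by MTT assay, with a stated time of 48 h; a lower number here means a stronger inhibitor, a higher number a weaker inhibitor:
Compound 1, `O=[N+]([O-])c1cc(C(F)(F)F)cc([N+](=O)[O-])c1Oc1ccccc1/C=N/OCc1ccccc1Cl`, gives 1430 nM.
Compound 2, `O=[N+]([O-])c1cc(C(F)(F)F)cc([N+](=O)[O-])c1Oc1ccc(Br)cc1/C=N\OCc1ccccc1`, gives 2240 nM.
Compound 3, `O=[N+]([O-])c1cc(C(F)(F)F)cc([N+](=O)[O-])c1Oc1ccc(Br)cc1/C=N/OCc1ccccc1Cl`, gives 3430 nM.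

Compound 1 and compound 3 differ in one place: bromo in place of hydrogen on an aromatic carbon. That change produced a 2.4-fold higher number from compound 1 to compound 3 (0.38 log units; beyond the scatter). Compound 2 and compound 3 also differ in one place, and there the step was a 1.5-fold higher number from compound 2 to compound 3 (0.19 log units; within the scatter). Compound 2 and compound 1 differ in more than one place, and the difference between the two cores is not broken down here.

Compound 4, `O=[N+]([O-])c1cc(C(F)(F)F)cc([N+](=O)[O-])c1Oc1c(Br)cc(Br)cc1/C=N\OCc1ccccc1`, has not yet been measured. It differs from compound 2 by bromo in place of hydrogen on an aromatic carbon. For the measured compounds named here, this is the same kind of change as the one from compound 1 to compound 3, but not the same: in compound 3 the entering bromo sits meta to a large group and para to a large group, whereas in compound 4 it sits ortho to a large group, meta to a bromo group and meta to a large group. Going by the values given here, with only one earlier example of this kind of change, and that in a different place, the expectation rests on it loosely. Compound 4 is expected to show a 2.0-fold higher number from compound 2 to compound 4 (0.30 log units; within the scatter), a step in the same direction and of similar size to the earlier 2.4-fold higher number from compound 1 to compound 3 (0.38 log units; beyond the scatter). The estimate for compound 4 in this assay is 4500 nM, with a range from 2200 nM to 9500 nM.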

Compound 4, half-maximal inhibitory concentration: 2150 nM
For compound 4 the middle estimate is 2.1-fold (0.32 log units) above the measured one; the whole stated range lies above it.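

In this assay, placing a bromo on the ring that already carries one gives a 1.0-fold lower number from compound 2 to compound 4 (0.02 log units; within the scatter), so this step shows no measurable effect of the added bromo on this core. Set beside the earlier step, where the same kind of change was made on another core, the two results cannot be told apart: the same change on two cores in this assay, a 2.4-fold higher number (0.38 log units; beyond the scatter) from compound 1 to compound 3 and a 1.0-fold lower number (0.02 log units; within the scatter) from compound 2 to compound 4, 2.5-fold (0.40 log units) apart, within the scatter of two such steps. For the compounds shown here, this does not show that the change carries over unchanged from one core to the other, nor that it behaves differently on each, since only one pair per core is available and the bromo enters at a different place in each pair, so the gap between the steps could reflect the core, the place or simple scatter.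

The compounds shown leave open whether a fluoro, a methoxy group or a nitrile, placed where the new bromo sits in compound 4, would read any differently from hydrogen or bromo. They also leave open whether the same bromo placed on a third core would follow the step seen on the core of compound 1 or the one seen on the core of compound 2.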